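From a Chlorophenyl to a Naphthyl Side Group

This account rests on a few compounds, and the source may have more. Where it says the series, first, only, none or still open, it means among the compounds named here.

In a physicochemical assay for lipophilicity (a higher number here means a more lipophilic compound, a lower number a more polar compound), compound 1 `COc1ccc(C(CC(=O)O)CC(=O)NNC(=O)c2cccc(NC(=N)N)c2)cc1` gives 1. Compound 2 `O=C(O)CC(NC(=O)NNC(=O)CCCCNc1ccccn1)c1ccc(Cl)cc1` gives 2.2 in this assay, the higher of the two numbers, with compound 1 standing lower by a gap beyond the usual scatter. Compound 3 `O=C(O)CC(NC(=O)NNC(=O)CCCCNc1ccccn1)c1cccc2ccccc12` has not yet been measured; it differs from compound 2 by naphthalen-1-yl in place of 4-chlorophenyl on a saturated chain carbon bound to an amide-type nitrogen and a saturated chain carbon. Among the measured compounds shown here, no measured pair shows this change, so the size of the step rests on expectation alone. In this assay the estimated step is a number 0.50 log units higher from compound 2 to compound 3 (beyond the scatter), upward and beyond the scatter. Compound 3 is therefore expected at 2.7, within a range of 2.2 to 3.2.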

Compound 3, partition coefficient: 2.64
Estimate against measurement, compound 3: 0.06 log units above, within the range that was stated.
By their numbers in this assay, from the lowest: compound 1; then compound 2; then compound 3.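

In this assay, naphthalen-1-yl in place of 4-chlorophenyl on a saturated chain carbon bound to an amide-type nitrogen and a saturated chain carbon gives a number 0.44 log units higher from compound 2 to compound 3 (beyond the scatter) as the first step read at a single place. Among the compounds shown here, compounds 1 and 2 differ in more than one place, so only this pair ties a change in the number to this position. Nothing measured here explains the step. The exchange removes the chlorine and adds a second aromatic ring together, and these two parts stay unseparated. From the compounds shown here alone, how a plain phenyl or a cyclohexyl group would stand at this place remains open.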